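The source may report more compounds than this note shows. Statements on the series, on what has been measured and on what is new or still open speak of the compounds shown alone.

Of the compounds shown here, three sharing one core have been tested in a functional assay on DU-145 cells (Homo sapiens) for antiproliferative activity, read by MTT assay, with a stated time of 72 h; a higher number here means a weaker inhibitor, a lower number a stronger inhibitor. Compound 1 `CN(c1ccccc1Cl)S(=O)(=O)C1CC2OC1C(c1ccc(NC(=O)CCCCCCC(=O)O)cc1)=C2c1ccc(O)cc1` gives 73500 nM. Compound 2 `CN(c1ccc(Cl)cc1)S(=O)(=O)C1CC2OC1C(c1ccc(NC(=O)CCCCCCC(=O)O)cc1)=C2c1ccc(O)cc1` gives 72100 nM, and the step is a 1.0-fold lower number from compound 1 to compound 2 (0.01 log units; within the scatter). Compound 3 `CCN(c1ccccc1)S(=O)(=O)C1CC2OC1C(c1ccc(NC(=O)CCCCCCC(=O)O)cc1)=C2c1ccc(O)cc1` reads > 100000 nM, which is a limit of the assay and not a number. Compound 4 `CCN(c1ccc(OC)cc1)S(=O)(=O)C1CC2OC1C(c1ccc(NC(=O)CCCCCCC(=O)O)cc1)=C2c1ccc(O)cc1` differs from compound 3 by one change methoxy in place of hydrogen on an aromatic carbon, para to a large group. Within the data shown here, no measured step tests a methoxy group. The closest evidence comes from swaps of the groups on the sulfonamide nitrogen: an at least 1.3-fold higher number from compound 1 to compound 3 (0.13 log units; that floor lies within the scatter), and an at least 1.3-fold higher number from compound 2 to compound 3 (0.14 log units; that floor lies within the scatter). Neither floor leaves the scatter, so no step beyond the scatter is expected in this assay. The estimate for compound 4 is 85000 nM, with an expected range from 45000 nM to 160000 nM.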

Compound 4, half-maximal inhibitory concentration: 24400 nM
For compound 4 the middle estimate is 3.5-fold (0.54 log units) above the measured one, and the stated range ends above it.
By their numbers in this assay, from the lowest: compound 4; then compounds 2 and 1 (each within the scatter of the next). At a limit, above all of these: compound 3.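

In this assay, methoxy in place of hydrogen on an aromatic carbon, para to a large group, gives a step that, unlike the earlier ones, lies beyond the scatter: an at least 4.0-fold lower number from compound 3 to compound 4 (0.61 log units; beyond the scatter). Compound 3 stands at a limit, so this step is only a floor: the limit of > 100000 nM in this assay, at which 1 of the 4 values shown sits. The ethyl(4-methoxyphenyl)amino group also separates compound 4 from both chlorine-bearing compounds, with a 3.0-fold lower number from compound 2 to compound 4 (0.47 log units; beyond the scatter) and a 3.0-fold lower number from compound 1 to compound 4 (0.48 log units; beyond the scatter).

On these data alone, what stays open is whether this effect is specific to methoxy. A hydroxyl, an amine or a fluorine at the same position, or methoxy elsewhere on that ring, would help to settle this.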